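Removing the second phosphorus unit: the step to compound 3

The compounds below may be only part of what the source reports. "The series", "measured", "known", "first", "only" and "open" are said of these compounds alone.

Compound 1 `Cn1c(=O)ccn([C@@H]2O[C@H](COP(=O)(O)OP(=O)(O)OP(=O)(O)O)[C@@H](O)[C@H]2O)c1=O` gives 564 nM in an in vitro functional assay on 1321-N1 cells for agonist activity at P2Y purinoceptor 2 (Homo sapiens); a higher number here means that more compound is needed for the effect, a lower number that less compound is needed. Compound 2 `Cn1c(=O)ccn([C@@H]2O[C@H](COP(=O)(O)OP(=O)(O)O)[C@@H](O)[C@H]2O)c1=O` gives > 1000 nM in this assay; that figure is a limit of the assay, not a number.

Compound 2 therefore stands at the weaker edge of what the assay can report, and only a limit is known for it (the limit of > 1000 nM in this assay, at which 1 of the 2 values shown sits). The step from compound 1 to compound 2 replaced a group of 4 heavy atoms (3 oxygen, 1 phosphorus; no ring) on an oxygen with a hydrogen atom, and it gave an at least 1.7-fold higher number from compound 1 to compound 2 (0.24 log units; that floor lies within the scatter).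

Compound 3 `Cn1c(=O)ccn([C@@H]2O[C@H](COP(=O)(O)O)[C@@H](O)[C@H]2O)c1=O` repeats the same kind of removal one unit further in: a hydrogen atom in place of a group of 4 heavy atoms (3 oxygen, 1 phosphorus; no ring), on an oxygen, on an oxygen whose other neighbour is phosphorus. Going by the values given here, the only measured step of this type, from compound 1 to compound 2, moved the number up at least to the limit. The same direction is expected here, so compound 3 is estimated to need more compound again, with a step that the limit leaves unreadable from compound 2 to compound 3 in this assay. Compound 3 is expected to give 5000 nM in this assay, within a range of 1000 nM to 30000 nM, and most likely the assay will again report only a limit.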

Compound 3, half-maximal effective concentration: > 100000 nM
Compound 3: a limit, no number (the forecaster's own chance of this, stated with the estimate: 85%); middle value at least 20-fold (1.30 log units) from the limit.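

Going by these compounds alone, removing both phosphorus units from the oxygen gives an at least 170-fold higher number from compound 1 to compound 3 (2.24 log units; beyond the scatter), so this series now has its first step at this position that is printed as beyond the scatter; the single removal from compound 1 to compound 2 could not show that. Within the data shown here, the chain on this oxygen therefore matters in this assay, at least when it is cut back to the one phosphorus unit of compound 3. The reading for compound 3 is itself a limit and not a number: the limit of > 100000 nM in this assay, at which 1 of the 3 values shown sits.

Compound 2 and compound 3 both carry only limits, so the step between them cannot be read, and the compounds shown do not tell how much of the total loss belongs to the first removal and how much to the second. Also open, going by these compounds, is what a longer phosphate chain, or a phosphonate or thiophosphate in place of a phosphate, would do on the same oxygen, and whether the number of compound 1 can be moved lower at all by any such change.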